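Widening a Saturated Ring: From Compound 1 to Compound 4

This account rests on a few compounds, and the source may have more. Where it says the series, first, only, none or still open, it means among the compounds named here.

Measured compounds:
compound 1 `CNC(=O)c1cc(Oc2ccc(Nc3nccc(N4CCCC4)n3)cc2)ccn1` gives 3410 nM
compound 2 `COc1ccc(C[C@H]2C(=O)N[C@@H](C)C(=O)N(C)[C@H]3Cc4cccc(c4)Oc4cc(ccc4O[C@H]4O[C@H](CO)[C@@H](O)[C@H](O)[C@H]4O)C[C@H](C(=O)N[C@H](C)C(=O)N[C@@H](C)C(=O)N2C)N(C)C3=O)cc1` gives 1340 nM
compound 3 `CN(c1ccc(Oc2ncnc3ccsc23)cc1)c1nccc(N2CCCC2)n1` gives 6510 nM

In a functional assay on A549 cells (Homo sapiens) for inhibition, read by MTT assay, with a stated time of 72 h (a lower number here means a stronger inhibitor, a higher number a weaker inhibitor), compound 1 stands second highest of the three numbers. Its nearest neighbour is compound 3, whose number is within the usual scatter of that of compound 1, so no order between the two can be claimed. Compound 2 sits furthest away, with a lower number beyond the scatter.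

Compound 4 `CNC(=O)c1cc(Oc2ccc(Nc3nccc(N4CCCCC4)n3)cc2)ccn1` has not yet been measured in this assay. It differs from compound 1 in one place: piperidin-1-yl in place of pyrrolidin-1-yl on an aromatic carbon. Within the data shown here, no measured pair in this set shows the same change, so nothing here gives its size directly. The change keeps one six-membered non-aromatic ring with one hetero atom in place of a five-membered one, with the same count of donors and acceptors and no net charge. The step of a 1.1-fold lower number from compound 1 to compound 4 (0.03 log units; within the scatter) is therefore expected to stay within the scatter, with no clear direction. Compound 4 is estimated at 3200 nM, with a range from 1100 nM to 9500 nM.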

Compound 4, half-maximal inhibitory concentration: 890 nM
The estimate for compound 4 lay 3.6-fold (0.56 log units) above the measured number; measured number outside the range, below it.
By their numbers in this assay, from the lowest: compounds 4 and 2 (each within the scatter of the next); then compounds 1 and 3 (each within the scatter of the next).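

In this assay the swap of pyrrolidin-1-yl for piperidin-1-yl on this aromatic carbon, next to the ring nitrogen, gives a 3.8-fold lower number from compound 1 to compound 4 (0.58 log units; beyond the scatter) even though the count of donors and acceptors and the absence of net charge stay the same. This single-place pair is the only direct sign in the set that the number responds to the saturated ring held at this position, and the step is modest in size. Nothing measured here accounts for the step.

Going by these compounds, whether a further widening to azepan-1-yl, a morpholin-4-yl ring or an open-chain dimethylamino group at the same place would keep the lower number remains open. Also open, on these data alone, is whether the same swap would act alike on the core of compound 3, which also carries pyrrolidin-1-yl.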